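Swapping the naphthyl ether for a chlorophenyl ether

The compounds below may be only part of what the source reports. "The series", "measured", "known", "first", "only" and "open" are said of these compounds alone.

Compound 2 `S=C(N/N=C/c1ccc(Oc2ccc3ccccc3c2)cc1)Nc1ccc(Br)cc1` gives 6.93 in a physicochemical assay for lipophilicity, in phosphate buffer, measured as octanol-water partition, with a stated time of 24 h (a lower number here means a more polar compound, a higher number a more lipophilic compound), the highest of the three values at hand. Compound 3 `Fc1ccc(NC(=S)N/N=C/c2ccc(Oc3ccc4ccccc4c3)cc2)cc1` gives 6.2 in this assay, and compound 1 `O=[N+]([O-])c1ccc(Oc2ccc(/C=N/NC(=S)Nc3ccc(Br)cc3)cc2)cc1` gives 5.68; the corresponding steps were a number 0.73 log units lower from compound 2 to compound 3 (beyond the scatter) and a number 1.25 log units higher from compound 1 to compound 2 (beyond the scatter). Compound 4 `S=C(N/N=C/c1ccc(Oc2ccc(Cl)cc2)cc1)Nc1ccc(Br)cc1` differs from compound 2 in one place: 4-chlorophenyl in place of naphthalen-2-yl on an oxygen on an aromatic ring. For the measured compounds named here, only the step from compound 1 to compound 2 touches this same position, and it was large. Compound 4 carries neither the nitrophenyl nor the naphthyl group, so a downward move of moderate size is expected in this assay, namely a number 0.53 log units lower from compound 2 to compound 4 (beyond the scatter). Compound 4 is therefore estimated at 6.4, with a likely range from 5.9 to 6.9.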

Compound 4, partition coefficient: 6.24
Beside the measured number, compound 4's estimate is 0.16 log units above it; the measured number falls inside the stated range.
By their numbers in this assay, from the lowest: compound 1; then compounds 3 and 4 (each within the scatter of the next); then compound 2.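

In this assay a single aromatic ring on the oxygen does not settle the number, since chloro in place of nitro gives a number 0.56 log units higher from compound 1 to compound 4 (beyond the scatter) with the ring count unchanged. The change to 4-chlorophenyl in place of naphthalen-2-yl gives a number 0.69 log units lower from compound 2 to compound 4 (beyond the scatter) and so the large earlier step at this position divides into two modest ones. No evidence at hand accounts for either move.

The compounds shown leave open how an amine or a carboxylic acid in place of the chloro would read. They also leave open whether these steps hold with fluoro in place of bromo.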